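This account rests on a few compounds, and the source may have more. Where it says the series, first, only, none or still open, it means among the compounds named here.

Working notes on the series. Compound 1 `CC1=CC[C@H](C(C)C)c2cc(C)c(OC(=O)Nc3ccccc3)cc21` and compound 2 `COc1ccc(C(=O)Oc2cc3c(C)ccc(C(C)C)c3cc2C)cc1` have been measured in a functional assay on HCT-15 cells (Homo sapiens) for antiproliferative activity, read by sulforhodamine B assay, with a stated time of 48 h, tested at 50 uM; on this read-out lower numbers stand for less inhibition and higher numbers for more inhibition at the one concentration tested (going by the name of the read-out). In this assay compound 1 gives 92%, and compound 2 gives 84%; these two values lie within the scatter of repeated measurements of this kind, so on the numbers shown compound 1 cannot be told apart from compound 2, and no step between measured compounds is available to calibrate the change now considered.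

Compound 3 `COc1ccc(C(=O)Oc2cc3c(cc2C)[C@@H](C(C)C)CC=C3C)cc1` has not yet been measured. It differs from compound 1 in one place: 4-methoxyphenyl in place of anilino on a carbonyl carbon. The core of compound 1 is kept unchanged. A step from compound 1 to compound 3 of a number 7 percentage points lower from compound 1 to compound 3 (within the scatter) is expected, that is no change beyond the scatter, with at most a small downward drift, because compound 2 carrying the same 4-methoxyphenyl group gives 84%. Compound 3 is therefore estimated to give 85% in this assay, with a range from 65% to 97%.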

Compound 3, a percentage reported as inhibition, at one concentration (the size of the read-out at that concentration, not a potency): 30.8%
The estimate for compound 3 lay 54.2 percentage points above the measured number; measured number below the stated range.
By their numbers in this assay, from the lowest: compound 3; then compounds 2 and 1 (each within the scatter of the next).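

For the compounds shown here, on the core of compound 1, 4-methoxyphenyl in place of anilino on a carbonyl carbon gives a number 61.2 percentage points lower from compound 1 to compound 3 (beyond the scatter) in this assay, so this position is sensitive to the group placed there, which the earlier values, with no one-place step between them, could not show. The change swaps a group counted with a hydrogen-bond donor for one counted with a hydrogen-bond acceptor, and it also swaps the nitrogen for a carbon on the carbonyl carbon. No measurement at hand bears on the cause of this step.

The compounds shown leave open whether the step follows the loss of the anilino nitrogen or the arrival of the methoxy group. A plain phenyl or a 4-methoxyanilino on the same carbonyl carbon would separate the two.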